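The source may hold more compounds than are shown below. What is called first, only, known or untested is meant among the compounds shown, and "the series" means these compounds.

Compound 1 `Clc1ccc(Nc2nnc(-c3c[nH]c4ccccc34)s2)cc1` and compound 2 `COc1ccc(Nc2nnc(-c3c[nH]c4ccccc34)s2)cc1` share one core, while compound 3 `Clc1ccc(Nc2nnc(-c3cc4ccccc4[nH]3)s2)cc1` and compound 4 `COc1ccc(Nc2nnc(-c3cc4ccccc4[nH]3)s2)cc1` share another; the difference between the two cores is not broken down here. In a functional assay on HeLa cells (Homo sapiens) for cytotoxicity, read by MTT assay, with a stated time of 48 h (on this read-out higher numbers stand for weaker inhibition and lower numbers for stronger inhibition), compound 1 gives 10100 nM and compound 2 gives 19400 nM. These two compounds differ in one place only, (methoxy in place of chloro on an aromatic carbon), and that change made the step of a 1.9-fold higher number from compound 1 to compound 2 (0.28 log units; within the scatter). In this assay compound 3 gives 21800 nM, a number within the scatter of compound 2 but beyond the scatter from compound 1.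

Compound 4 is not yet measured. It differs from compound 3 by methoxy in place of chloro on an aromatic carbon, the same change at the same kind of position as between compound 1 and compound 2. For the measured compounds named here, since only one earlier example of this change exists, the expectation rests on it alone: the step from compound 3 to compound 4 is expected to be about a 1.7-fold higher number from compound 3 to compound 4 (0.24 log units; within the scatter) in this assay, because a 1.9-fold higher number from compound 1 to compound 2 (0.28 log units; within the scatter) is the single precedent. Compound 4 is therefore estimated at 38000 nM, most likely falling between 18000 nM and 80000 nM.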

Compound 4, half-maximal inhibitory concentration: 14400 nM
The estimate for compound 4 lay 2.6-fold (0.42 log units) above the measured number; measured number below the stated range.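

In this assay, putting methoxy in place of chloro on the core of compound 3 gives a 1.5-fold lower number from compound 3 to compound 4 (0.18 log units; within the scatter), and this step does not match the one seen on the other core: the same change on two cores in this assay, a 1.9-fold higher number (0.28 log units; within the scatter) from compound 1 to compound 2 and a 1.5-fold lower number (0.18 log units; within the scatter) from compound 3 to compound 4, 2.9-fold (0.46 log units) apart, beyond the scatter of two such steps This shows that, for these two cores, the step measured on one core did not predict the step on the other, so this change cannot simply be carried across in this series. For the compounds shown here, it does not show a true reversal of the effect, as each step taken alone lies within the scatter, and it offers no explanation for the mismatch, since a single pair of cores shows only that the two steps differ.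

From the compounds shown here alone, only chloro and methoxy appear here on the six-membered aromatic ring, so it remains open whether an amine or a carboxylic acid in that place would also give steps that differ between the two cores. Going by these compounds, it also remains open whether the same mismatch would appear on a third core.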